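The source may report more compounds than this note shows. Statements on the series, on what has been measured and on what is new or still open speak of the compounds shown alone.

Within the data shown here, compound 2 `Cc1cnn(-c2ccncc2N2CCC(C(=O)N(C)C)CC2)c1` gives the lower of the two numbers measured so far: in an assay on HEK293F cells for inhibition of cholesterol 24-hydroxylase (Homo sapiens), read by trypan blue exclusion, with stated times of 15 min and 5 h (on this read-out higher numbers stand for weaker inhibition and lower numbers for stronger inhibition), compound 2 gives 8.5 nM. Compound 1 `CN(C)C(=O)C1CCN(c2cnccc2-n2cccn2)CC1` differs from it only by lacking the methyl on the five-membered ring; in this assay compound 1 gives 48 nM, and the step of a 5.6-fold lower number from compound 1 to compound 2 (0.75 log units; beyond the scatter) shows what adding that methyl did. Compound 3 `Cc1ccn(-c2ccncc2N2CCC(C(=O)N(C)C)CC2)n1` keeps every atom of compound 2 but joins them differently: 3-methyl-1H-pyrazol-1-yl in place of 4-methyl-1H-pyrazol-1-yl on an aromatic carbon. Among the measured compounds shown here, no measured step moves a methyl from one place on this ring to another, so the only guide is the step from compound 1 to compound 2, which sets the scale of what a methyl on this ring has been worth. Shifting the methyl rather than removing it is expected to cost less than removing it outright, so a step of a 2.4-fold higher number from compound 2 to compound 3 (0.37 log units; beyond the scatter) toward a higher number is expected. Compound 3 is therefore estimated at 20 nM, with a range from 6 nM to 70 nM.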

Compound 3, half-maximal inhibitory concentration: 1100 nM
Estimate against measurement, compound 3: 55-fold (1.74 log units) below, outside the stated range (above it).
By their numbers in this assay, from the lowest: compound 2; then compound 1; then compound 3.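

In this assay the place of the methyl on the five-membered aromatic ring matters more than its presence: moving it gives a 130-fold higher number from compound 2 to compound 3 (2.11 log units; beyond the scatter) even though the two groups hold the same atoms. A methyl is therefore not a gain wherever it is put, since adding one as 3-methyl-1H-pyrazol-1-yl gives a 23-fold higher number from compound 1 to compound 3 (1.36 log units; beyond the scatter) and so runs against a 5.6-fold lower number from compound 1 to compound 2 (0.75 log units; beyond the scatter) in direction. Nothing measured here accounts for this difference between the two methyl groups.

From the compounds shown here alone, whether an ethyl group or a chlorine atom in place of the methyl of the 4-methyl-1H-pyrazol-1-yl group would lower the number further stays open. So does whether the loss seen with 3-methyl-1H-pyrazol-1-yl would also appear with a group other than methyl, such as methoxy.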